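A few compounds are considered here, and "the series" means these few. Any claim that something is new, unique, unknown or untested is made for them only; others in the source may bear on it.

Compound 1 `COc1ccc(Cn2c(C(=O)O)c(CNCc3cccc(OC)c3)c3ccc(C(F)(F)F)cc32)cc1`: > 50000 nM
Compound 2 `COc1ccc(Cn2c(C(=O)O)c(CNCc3cccc(OC)c3)c3ccc(C)cc32)cc1`: 9830 nM

Going by the values given here, in a functional assay on Bel-7402 cells (Homo sapiens) for antiproliferative activity, read by MTT assay, with a stated time of 72 h (on this read-out higher numbers stand for weaker inhibition and lower numbers for stronger inhibition), compound 2 gives 9830 nM, the only exact number so far. The entry for compound 1 is a limit of the assay and not a number: > 50000 nM.

Compound 3 `COc1ccc(Cn2c(C(=O)O)c(CNCc3cccc(O)c3)c3ccc(C)cc32)cc1` keeps compound 2 unchanged except for one place: hydrogen in place of methyl on an oxygen on an aromatic ring. This is hydrogen in place of methyl on an oxygen on an aromatic ring, so 3-methoxybenzyl becomes 3-hydroxybenzyl.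

Among the compounds with values here, the single measured step, an at least 5.0-fold lower number from compound 1 to compound 2 (0.70 log units; beyond the scatter), involves a different place in the molecule. It gives no direct size for this change, but it does show that one small substitution can shift the result beyond the scatter. With no direction favoured, the expected step in this assay is a 1.0-fold higher number from compound 2 to compound 3 (0.01 log units; within the scatter), which would not go beyond the scatter. Compound 3 is estimated at 10000 nM, with an expected range of 3000 nM to 33000 nM.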

Compound 3, half-maximal inhibitory concentration: 19800 nM
Estimate against measurement, compound 3: 2.0-fold (0.30 log units) below; the measured number falls inside the stated range.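

Taking the methyl off the oxygen of the 3-methoxybenzyl group is the first change shown on this side of the molecule, and in this assay it gives a 2.0-fold higher number from compound 2 to compound 3 (0.30 log units; within the scatter). Compound 2 and compound 3 therefore cannot be told apart here, so this swap of methoxy for hydroxy, unlike the swap of trifluoromethyl for methyl, has no readable effect on the result. Compound 1 remains the only compound whose entry is a limit of the assay and not a number: the limit of > 50000 nM in this assay, at which 1 of the 3 values shown sits.

What the compounds shown leave open is whether a different group on this ring, such as an amine, a fluorine or a longer ethoxy chain, would move the number beyond the scatter. A single step at this place also gives no trend and no cause for the result.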